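Series notes: chain amine exchange, compound 2 to compound 4

The compounds below may be only part of what the source reports. "The series", "measured", "known", "first", "only" and "open" are said of these compounds alone.

Measured compounds in a functional assay on NCI-H661 cells (Homo sapiens) for cytotoxicity, read by WST assay, with a stated time of 72 h; on this read-out higher numbers stand for weaker inhibition and lower numbers for stronger inhibition:
compound 1, `CCN(CC)CCCOc1cc2ncnc(Nc3nc4ccc(C(=O)Nc5c(C)cccc5C)cc4s3)c2cc1OC`, gives 66500 nM.
compound 2, `CCN(CC)CCCOc1cc2ncnc(Nc3nc4ccc(C(=O)Nc5c(C)cccc5Cl)cc4s3)c2cc1OC`, gives 11200 nM.
compound 3, `COc1cc2c(Nc3nc4ccc(C(=O)Nc5c(C)cc(C)cc5C)cc4s3)ncnc2cc1OCCCN1CCCC1`, gives 9600 nM.

Compound 2 holds the second highest of the three numbers. Among the compounds with values here, its nearest neighbour is compound 3, which sits within the scatter of it; its furthest is compound 1, separated by a 5.9-fold lower number from compound 1 to compound 2 (0.77 log units; beyond the scatter), the only single-point step measured so far, and one that concerns the aryl amide rather than the chain.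

Compound 4, `COc1cc2c(Nc3nc4ccc(C(=O)Nc5c(C)cccc5Cl)cc4s3)ncnc2cc1OCCCN1CCCCC1`, differs from compound 2 in one place: piperidin-1-yl in place of diethylamino on a saturated chain carbon, three bonds along the chain from an oxygen on an aromatic ring. Within the data shown here, no measured step tracks this exchange. Compound 3 carries a pyrrolidin-1-yl on its chain, but its aryl amide also differs from that of compound 2, so its number can only be set beside the number of compound 2, and the two lie within the scatter. On this basis no step beyond the scatter is expected for compound 4 in this assay in either direction, a 1.1-fold lower number from compound 2 to compound 4 (0.05 log units; within the scatter).

Compound 4 is therefore estimated at 10000 nM, with a range from 4000 nM to 25000 nM.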

Compound 4, half-maximal inhibitory concentration: 13800 nM
The estimate for compound 4 lay 1.4-fold (0.14 log units) below the measured number; the range from low to high includes it.
By their numbers in this assay, from the lowest: compounds 3, 2 and 4 (each within the scatter of the next); then compound 1.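

In this assay, within the data shown here, the chain amine is read directly for the first time, with the aryl amide and the rest of compound 2 held constant: the exchange gives a 1.2-fold higher number from compound 2 to compound 4 (0.09 log units; within the scatter). Among these compounds, at this place on the chain, replacing open diethylamino with the ring of piperidin-1-yl, at 6 heavy atoms against 5 and with the same printed hydrogen-bond counts, therefore produces no step beyond the scatter, whereas the aryl amide change gives a 5.9-fold lower number from compound 1 to compound 2 (0.77 log units; beyond the scatter) and remains the only step beyond it so far. No supporting measurement is available to explain this result.

The compounds shown leave open whether the same outcome holds for a morpholine ring, a piperazine ring, dimethylamino or a primary amine at the chain end, or for a hydroxyl group in place of the amine. They also leave open whether a shorter or longer chain, or the piperidin-1-yl exchange carried out on the aryl amide of compound 1, would stay within the scatter of its direct partner.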